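The source may report more compounds than this note shows. Statements on the series, on what has been measured and on what is new or still open speak of the compounds shown alone.

Measured so far in a functional assay on MGC-803 cells (Homo sapiens) for inhibition, read by CCK-8 assay, with a stated time of 48 h; a lower number here means a stronger inhibitor, a higher number a weaker inhibitor
compound 1 `COc1ccc(CN(C(=O)CSC(=S)N2CCc3cc(OC)ccc32)c2cc(OC)c(OC)c(OC)c2)cc1` gives 11700 nM
compound 2 `COc1ccc(CN(C(=O)CSC(=S)N2CCc3ccccc3C2)c2cc(OC)c(OC)c(OC)c2)cc1` gives 5940 nM
compound 3 `COc1cc(N(Cc2ccc(Br)cc2)C(=O)CSC(=S)N2CCN(C(=O)OC(C)(C)C)CC2)cc(OC)c1OC` gives 12400 nM

Compound 3 at 12400 nM sits within the scatter of compound 1, while compound 2 at 5940 nM shows a lower number than compound 3 by slightly more than the scatter.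

Compound 4 `COc1ccc(CN(C(=O)CSC(=S)N2CCN(C(=O)OC(C)(C)C)CC2)c2cc(OC)c(OC)c(OC)c2)cc1N` differs from compound 3 in one place (3-amino-4-methoxyphenyl in place of 4-bromophenyl on a saturated chain carbon bound to an amide-type nitrogen), with 3-amino-4-methoxyphenyl in place of 4-bromophenyl on a saturated chain carbon bound to an amide-type nitrogen.

Among the compounds with values here, the only measured single-place step (a 2.0-fold lower number from compound 1 to compound 2 (0.29 log units; within the scatter)) is on a thiocarbonyl carbon, not at this place, and it lies within the scatter. It therefore gives no direct size for this change. Within the data shown here, the data hold no measured step at this place, so no shift beyond the scatter is expected in this assay, and the range is kept wide.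

The expected step is a 1.8-fold lower number from compound 3 to compound 4 (0.25 log units; within the scatter) (an estimate only).

For compound 4 the estimated value is 7000 nM with an expected range from 1000 nM to 20000 nM (in the same read-out).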

Compound 4, half-maximal inhibitory concentration: 184 nM
Beside the measured number, compound 4's estimate is 38-fold (1.58 log units) above it; the whole stated range lies above it.
By their numbers in this assay, from the lowest: compound 4; then compounds 2, 1 and 3 (each within the scatter of the next, the first and the last beyond it).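

At the saturated chain carbon bound to an amide-type nitrogen, the choice of aryl group has a large effect in this assay: 3-amino-4-methoxyphenyl in place of 4-bromophenyl gives a 67-fold lower number from compound 3 to compound 4 (1.83 log units; beyond the scatter) in this series. The only earlier single-place step, a 2.0-fold lower number from compound 1 to compound 2 (0.29 log units; within the scatter), lies on a thiocarbonyl carbon and stays within the scatter, so this is the first step shown to exceed it and the first size available for this position. No measurement at hand explains the step.

The compounds shown do not separate the contribution of the amine from that of the methoxy group, and a hydroxyl or an acetamide in place of the amine would test how specific the step is to that group. Going by these compounds, whether a step of this size carries over to other groups on the thiocarbonyl carbon also remains open.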